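A Halogen Swap on the Benzylsulfanyl Arm

The source may report more compounds than this note shows. Statements on the series, on what has been measured and on what is new or still open speak of the compounds shown alone.

Compound 1 `Cc1cc(Nc2cc(-c3ccccc3)[nH]n2)n2nc(SCCCc3ccccc3)nc2n1`: 3900 nM
Compound 2 `Cc1cc(Nc2cc(-c3ccccc3)[nH]n2)n2ncnc2n1`: > 50000 nM, a limit of the assay
Compound 3 `Cc1cc(Nc2cc(-c3ccccc3)[nH]n2)n2nc(SCc3ccc(Cl)cc3)nc2n1`: 8260 nM

All three compounds share one core and were tested in a functional assay on MCF7 cells (Homo sapiens) for inhibition, read by MTT assay, with a stated time of 72 h; on this read-out higher numbers stand for weaker inhibition and lower numbers for stronger inhibition. Compound 2 reaches only a limit of the assay, (the limit of > 50000 nM in this assay, at which 1 of the 3 values shown sits). Among the two numbers given, compound 3 stands highest, so it is the weaker inhibitor of the pair: there is a 2.1-fold higher number from compound 1 to compound 3 (0.33 log units; beyond the scatter), and there is an at least 6.0-fold lower number from compound 2 to compound 3 (0.78 log units; beyond the scatter).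

Compound 4 `Cc1cc(Nc2cc(-c3ccccc3)[nH]n2)n2nc(SCc3cccc(Br)c3)nc2n1` differs from compound 3 in one place: 3-bromophenyl in place of 4-chlorophenyl on a saturated chain carbon bound to a sulfur. Within the data shown here, no measured step exchanges one halogenated phenyl for another; the only step touching the same chain carbon is a 2.1-fold higher number from compound 1 to compound 3 (0.33 log units; beyond the scatter), which was modest. The change from compound 3 to compound 4 is smaller in kind than that one, so no step beyond the scatter is expected, and a 1.0-fold lower number from compound 3 to compound 4 (0.01 log units; within the scatter) is the estimated outcome. Compound 4 is therefore expected to give about 8000 nM in this assay, with a likely range from 3000 nM to 20000 nM.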

Compound 4, half-maximal inhibitory concentration: 5140 nM
Compound 4: the middle estimate sits 1.6-fold (0.19 log units) above what was measured; the range from low to high includes it.
By their numbers in this assay, from the lowest: compounds 1, 4 and 3 (each within the scatter of the next, the first and the last beyond it). At a limit, above all of these: compound 2.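

In this assay, the arm on the saturated chain carbon bound to a sulfur accepts a new halogen at a new place on the ring with no change beyond the scatter, as a 1.6-fold lower number from compound 3 to compound 4 (0.21 log units; within the scatter) shows, and a 1.3-fold higher number from compound 1 to compound 4 (0.12 log units; within the scatter) likewise puts this arm level with the (3-phenylpropyl)sulfanyl arm, so compound 4 sits within the scatter of both earlier compounds even though those two are separated by more than the scatter. A second halogenated benzylsulfanyl arm also clearly outperforms a bare hydrogen on the aromatic carbon, with an at least 9.7-fold lower number from compound 2 to compound 4 (0.98 log units; beyond the scatter). Compound 2 gives only a limit of the assay, so the true size of that step stays unknown: the limit of > 50000 nM in this assay, at which 1 of the 4 values shown sits.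

The 3-bromophenyl group changes both the halogen and its place at once, and only a 3-chlorobenzyl or 4-bromobenzyl arm could separate the two. On these data alone, whether a carboxylic acid or an amine on that ring would hold the same level also remains open.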